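The source may hold more compounds than are shown below. What is called first, only, known or untested is meant among the compounds shown, and "the series" means these compounds.

Compound 1 `CC(C)CCc1sc(NC(=O)c2cc(NC(=O)c3cc(NC(=N)c4ccc(F)cc4)cn3C)cn2C)nc1C(=O)NCCCN(C)C` was tested in an assay on nucleic acid for binding affinity to Salmon testes DNA (Salmonidae), tested at 10 uM (on this read-out lower numbers stand for weaker stabilisation of the target and higher numbers for stronger stabilisation of the target against heat), and gave 9 degrees C, the lower of the two numbers in hand. Compound 2 `CN(C)CCCNC(=O)c1cc(NC(=O)c2cc(NC(=O)c3cc(NC(=N)c4ccccc4)cn3C)cn2C)cn1C` gave 11 degrees C in this assay, a reading that sits above compound 1 by more than the usual scatter. Compound 3 `CC(C)CCc1sc(NC(=O)c2cc(NC(=O)c3cc(NC(=N)c4ccc(Cl)cc4)cn3C)cn2C)nc1C(=O)NCCCN(C)C` differs from compound 1 in one place: chloro in place of fluoro on an aromatic carbon. Among the measured compounds shown here, with no measured step of this kind to lean on, the expected change from compound 1 to compound 3 is a number 0.50 degrees C higher from compound 1 to compound 3 (within the scatter), that is none beyond the scatter. Compound 3 is therefore expected to give about 9.5 degrees C in this assay, within a range from 7.5 degrees C to 12 degrees C.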

Compound 3, shift of the target's melting temperature: 4 degrees C
For compound 3 the middle estimate is 5.5 degrees C above the measured one, outside the stated range (below it).
By their numbers in this assay, from the lowest: compound 3; then compound 1; then compound 2.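

In this assay, the exchange of 4-fluorophenyl for 4-chlorophenyl gives a number 5.0 degrees C lower from compound 1 to compound 3 (beyond the scatter), so this aromatic carbon, para to a large group, is sensitive to which halogen it carries, even though the two groups have the same heavy-atom count and neither has hydrogen-bond donors or acceptors. Compound 1 and compound 2 differ in more than one place, so they could not isolate this position. No evidence at hand explains the step. On these data alone, what bromo, methoxy or a nitrile on this carbon would give in this assay remains open.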